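Swapping chloro for diethylamino on an inactive ATM scaffold

The source may report more compounds than this note shows. Statements on the series, on what has been measured and on what is new or still open speak of the compounds shown alone.

Compound 2 `COc1cc2nc(Cl)nc(-n3nc(-c4ccccn4)nc3N)c2cc1OC`: > 40000 nM
Compound 1 `Nc1nc(-c2ccccn2)nn1-c1ncnc2cc(OC(F)(F)F)ccc12`: > 40000 nM

In an assay on MCF7 cells for inhibition of Serine-protein kinase ATM (Homo sapiens), read by immunofluorescence, with a stated time of 1 h (on this read-out higher numbers stand for weaker inhibition and lower numbers for stronger inhibition), compound 2 reaches only a limit of the assay, > 40000 nM. Compound 1 likewise gives only a limit, > 40000 nM. Both readings sit at the limit of > 40000 nM in this assay, at which 2 of the 2 values shown sit, so neither is a true number. Compound 3 `CCN(CC)c1nc(-n2nc(-c3ccccn3)nc2N)c2cc(OC)c(OC)cc2n1` differs from compound 2 by diethylamino in place of chloro on an aromatic carbon. Among the measured compounds shown here, no measured step between compounds exists here, so the change offers no guide; the step of a number no higher from compound 2 to compound 3 (the limit leaves the size open) is expected to stay within scatter. Compound 3 is expected at 40000 nM, between 10000 nM and 100000 nM, most likely again as a limit.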

Compound 3, half-maximal inhibitory concentration: > 40000 nM
Compound 3 gave a limit, no number; the forecaster's own chance of this, stated with the estimate: 70%; the middle value lies on the limit itself.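

Compound 2 and compound 3 both give only a limit, so no step between them can be read: the limit of > 40000 nM in this assay, at which 3 of the 3 values shown sit.

The compounds shown leave open whether diethylamino in place of chloro changes inhibition of ATM at all.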